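The compounds below may be only part of what the source reports. "The series", "measured", "known", "first", "only" and "open" are said of these compounds alone.

The measured compounds are compound 1 `COc1ccccc1N1CCN(CCCCn2nc(-n3cnc4ccccc43)ccc2=O)CC1` and compound 2 `COc1ccccc1N1CCN(CCCCCCCn2nc(-n3cnc4ccccc43)ccc2=O)CC1`. In an assay on cell membranes from brain for binding affinity to Adrenergic receptor alpha-1 (Rattus norvegicus), read by radioligand binding (a lower number here means a stronger inhibitor, a higher number a weaker inhibitor), compound 1 gives 1.1 nM, and in this assay compound 2 gives 1.7 nM.

Compound 1 carries the lower of the two numbers, but its gap to compound 2 sits within the scatter of this kind of measurement, so the two cannot be ranked. Among the compounds with values here, the two compounds differ in the length of the chain joining the two ends of the shared core, and no step between them is counted here; their two values simply read as close.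

Compound 3 `O=c1ccc(-n2cnc3ccccc32)nn1CCCCN1CCN(c2ccccc2Cl)CC1` has not yet been measured. Its change from compound 1 is chloro in place of methoxy on an aromatic carbon. Within the data shown here, the measured pair offers no step of this kind, so the expectation rests on the change itself rather than on a comparable move. A small loss of affinity, or none beyond the scatter, is the expectation; the step from compound 1 to compound 3 is estimated at a 2.7-fold higher number from compound 1 to compound 3 (0.44 log units; beyond the scatter). For compound 3 the value in this assay is expected to be about 3 nM, with a range from 1 nM to 12 nM.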

Compound 3, inhibition constant: 1.3 nM
The estimate for compound 3 lay 2.3-fold (0.36 log units) above the measured number; measured number inside the range.
By their numbers in this assay, from the lowest: compounds 1, 3 and 2 (each within the scatter of the next).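

In this assay, replacing 2-methoxyphenyl with 2-chlorophenyl gives a 1.2-fold higher number from compound 1 to compound 3 (0.07 log units; within the scatter), so at this place on an aromatic carbon, ortho to a large group, the two groups cannot be told apart. Within the data shown here, the earlier pair differed only in the chain joining the two ends of the shared core, whereas this step is the first to change the aromatic end, and it shows that the value holds when methoxy, with its 1 hydrogen-bond acceptor, gives way to chloro, with 0: compound 3 gives 1.3 nM. Nothing available explains why the two groups read alike.

The compounds shown leave open whether any group at this place would separate from these two, such as a hydrogen, a fluoro, a hydroxyl or a trifluoromethyl, and whether chloro would read the same on another carbon of this ring. They also leave open whether the change from methoxy to chloro would hold on the longer chain of compound 2, since the chloro group appears here only with the shorter chain of compound 3.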